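Compound 3 and its expected cyano analogue

A few compounds are considered here, and "the series" means these few. Any claim that something is new, unique, unknown or untested is made for them only; others in the source may bear on it.

In a functional assay (aorta) with Rattus norvegicus as the target, in the presence of a further agent that is not named here (a lower number here means that less compound is needed, a higher number that more compound is needed for the effect), compound 1 `COC(=O)C1=C(C)N=C(C)/C(=C(/O)OC)C1c1cccc(OCc2nonc2C)c1` gives 640 nM while compound 2 `COC(=O)C1=C(C)N=C(C)/C(=C(/O)OC)C1c1cccc(OCc2nonc2C(N)=O)c1` gives 3500 nM and compound 3 `COC(=O)C1=C(C)N=C(C)/C(=C(/O)OC)C1c1cccc(OCc2no[n+]([O-])c2C(N)=O)c1` gives 710 nM on the same core. Compound 3 therefore stands level with compound 1 within the scatter (a 1.1-fold higher number from compound 1 to compound 3 (0.05 log units; within the scatter)) and clearly below compound 2 (a 4.9-fold lower number from compound 2 to compound 3 (0.69 log units; beyond the scatter)).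

Compound 4 `COC(=O)C1=C(C)N=C(C)/C(=C(/O)OC)C1c1cccc(OCc2nonc2C#N)c1` alters the group on a saturated chain carbon bound to an oxygen on an aromatic ring (a group of 7 heavy atoms (3 carbon, 3 nitrogen, 1 oxygen; one five-membered aromatic ring with 3 hetero atoms) in place of a group of 9 heavy atoms (3 carbon, 3 nitrogen, 3 oxygen; one five-membered aromatic ring with 3 hetero atoms), on a saturated chain carbon bound to an oxygen on an aromatic ring), and 4-cyano-1,2,5-oxadiazol-3-yl enters there. Going by the values given here, no measured step makes this exact change. Two modest steps give the nearest guidance: the carbamoyl for methyl exchange (a 5.5-fold higher number from compound 1 to compound 2 (0.74 log units; beyond the scatter)) and the step that removes most of that gap (a 4.9-fold lower number from compound 2 to compound 3 (0.69 log units; beyond the scatter)). Compound 4 lacks the ring oxide of compound 3, as do compound 1 and compound 2, so it is expected to fall within the span of those two. A small upward step near the edge of the scatter is expected (a 2.1-fold higher number from compound 3 to compound 4 (0.32 log units; beyond the scatter)). The estimate for compound 4 is 1500 nM (range 500 nM to 4500 nM).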

Compound 4, half-maximal effective concentration: 310 nM
Compound 4: the middle estimate sits 4.8-fold (0.68 log units) above what was measured, outside the stated range (below it).
By their numbers in this assay, from the lowest: compound 4; then compounds 1 and 3 (each within the scatter of the next); then compound 2.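

At this place, on a saturated chain carbon bound to an oxygen on an aromatic ring, the 4-cyano-1,2,5-oxadiazol-3-yl group of compound 4 gives the lowest number of the series in this assay, and replacing methyl with cyano on the aromatic carbon moves the number down (a 2.1-fold lower number from compound 1 to compound 4 (0.31 log units; beyond the scatter)), whereas carbamoyl had moved it up. Going by these compounds alone, the change from carbamoyl to cyano on that carbon is the only large step in the set (an 11-fold lower number from compound 2 to compound 4 (1.05 log units; beyond the scatter)), so the outcome depends strongly on which of these groups stands there. The ring oxide of compound 3 is also not required for a low number, since a ring without it goes lower still (a 2.3-fold lower number from compound 3 to compound 4 (0.36 log units; beyond the scatter)).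

As far as these compounds go, whether an amine or a carboxylic acid on that aromatic carbon would track the cyano or the carbamoyl result remains open, as does the effect of adding the ring oxide to compound 4. Nothing available here bears on why these numbers differ.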